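Swapping the phenyl for a nitro-methoxy ring

The compounds below may be only part of what the source reports. "The series", "measured", "known", "first", "only" and "open" are said of these compounds alone.

Compound 1 `O=C(/C=C/c1cccc(NC(=O)Nc2ccccc2)c1)C[C@@H]1O[C@H](CO)[C@@H](O)[C@H](O)[C@H]1O` was tested in an ADME assay on Vero cells (Chlorocebus sabaeus) for cytotoxicity, read by resazurin assay, with a stated time of 2 days (a higher number here means that more compound is tolerated, a lower number that less compound is tolerated), and gives 373000 nM, the highest of the two numbers available. Compound 3 `CC(=O)OC[C@H]1O[C@@H](CC(=O)/C=C/c2cccc(NC(=S)Nc3ccccc3)c2)[C@@H](OC(C)=O)[C@@H](OC(C)=O)[C@@H]1OC(C)=O` gives 65100 nM, a gap beyond the usual scatter. Compound 2 `O=C(/C=C/c1cccc(NC(=O)Nc2ccccc2)c1)C[C@@H]1O[C@H](CO)[C@@H](O)[C@H](O)[C@@H]1O` gives "not determined" (no result reported) in this assay, so no number is reported for it; its relation to compound 1 is the fact that compounds 1 and 2 differ only in the configuration as drawn.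

Compound 4 `COc1ccc(NC(=O)Nc2cccc(/C=C/C(=O)C[C@@H]3O[C@H](CO)[C@@H](O)[C@H](O)[C@H]3O)c2)c([N+](=O)[O-])c1` is compound 1 with 4-methoxy-2-nitrophenyl in place of phenyl on an amide-type nitrogen. Among the measured compounds shown here, with no directly comparable measured pair to lean on, the expectation is a modest decrease in the tolerated concentration, and it is estimated that the step of a 1.9-fold lower number from compound 1 to compound 4 (0.27 log units; within the scatter) may reach the edge of the scatter rather than clearly beyond it. Compound 4 is therefore expected to give about 200000 nM, within a range from 60000 nM to 450000 nM.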

Compound 4, half-maximal cytotoxic concentration: 709000 nM
For compound 4 the middle estimate is 3.5-fold (0.55 log units) below the measured one, and the stated range ends below it.
By their numbers in this assay, from the lowest: compound 3; then compounds 1 and 4 (each within the scatter of the next).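

In this assay, among the compounds shown here, putting 4-methoxy-2-nitrophenyl in place of phenyl on the amide-type nitrogen gives a 1.9-fold higher number from compound 1 to compound 4 (0.28 log units; within the scatter), the first single-place step that can be read here. This position therefore accepts the larger substituted ring with no change beyond the scatter, and compounds 1 and 4 cannot be told apart in how well they are tolerated. Nothing available explains this result. Still open, going by these compounds, is whether methoxy or nitro alone would give the same picture, and whether an amine or a carboxylic acid on this ring would be tolerated equally well.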